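This account rests on a few compounds, and the source may have more. Where it says the series, first, only, none or still open, it means among the compounds named here.

Measured so far in a functional assay on isolated protein for agonist activity at Free fatty acid receptor 1 (Homo sapiens), read by HTRF and inositol phosphate accumulation, with a stated time of 60 min; on this read-out lower numbers stand for an effect already at smaller amounts and higher numbers for an effect only at larger amounts of compound:

- compound 1 `O=C(O)CCCOc1ccc(-c2cc(OC(F)(F)F)ccc2F)cc1`: 4220 nM
- compound 2 `O=C(O)CCCOc1ccc(-c2ccccc2Oc2ccccc2)cc1`: > 9950 nM
- compound 3 `O=C(O)CCCOc1ccc(-c2cc(Oc3cccc(F)c3)ccc2Cl)cc1`: 3350 nM

Compound 1, at 4220 nM in this assay, and compound 3, at 3350 nM, sit within the scatter of each other, so no order between the two can be read from these numbers. For compound 2 the result in this assay is a limit rather than a number, (the limit of > 9950 nM in this assay, at which 1 of the 3 values shown sits), and nothing further can be drawn from it. Compound 1 thus stands among the measured numbers without being set apart from compound 3.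

Compound 4 `O=C(O)CCCOc1ccc(-c2cc(OC3CC3)ccc2F)cc1` has not yet been measured. It differs from compound 1 in one place: cyclopropyl in place of trifluoromethyl on an oxygen on an aromatic ring. Among the compounds with values here, no measured pair in this set carries the same change, so neither size nor direction of this step is anchored by a measured step. Both the group that leaves and the group that enters are neutral and carry neither donors nor acceptors; on that basis the expected step of a 1.1-fold lower number from compound 1 to compound 4 (0.05 log units; within the scatter) in this assay is none beyond the scatter. Compound 4 is accordingly estimated at 3800 nM, with an expected range from 1500 nM to 9500 nM, the limit of the assay remaining a possible outcome.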

Compound 4, half-maximal effective concentration: > 9950 nM
Compound 4: only a limit was reported; the forecaster's own chance of this, stated with the estimate: 20%; at least 2.6-fold (0.41 log units) between middle value and limit.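

Cyclopropyl in place of trifluoromethyl on an oxygen on an aromatic ring gives an at least 2.3-fold higher number from compound 1 to compound 4 (0.37 log units; beyond the scatter) in this assay, the only step in the series so far that can be read, and it lies beyond the scatter. The read-out at this position therefore responds to the group on the oxygen, even though the group that leaves and the group that enters are both neutral, carry no hydrogen-bond donors or acceptors and differ by only one heavy atom. For compound 4, the result in this assay is a limit and not a number, making it the second such result among the compounds shown: the limit of > 9950 nM in this assay, at which 2 of the 4 values shown sit.

The full size of this step remains open, as only its lower bound can be read, and this single pair gives no basis for saying which feature of either group accounts for it. From the compounds shown here alone, it is also open whether another group on the same oxygen, such as methyl, difluoromethyl or a longer carbon chain, would stay close to compound 1 or fall away as compound 4 does.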